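Formyl on the ring amine nitrogen: three measured, one pending

The source may report more compounds than this note shows. Statements on the series, on what has been measured and on what is new or still open speak of the compounds shown alone.

Of the compounds shown here, three of the shared core have been measured in a functional assay on the whole organism (strain Wistar) for inhibition, with Rattus norvegicus as the target, read by paw edema, with stated times of 30 min and 120 min, at a dose of 50 mg/kg by the oral route; on this read-out higher numbers stand for more inhibition at the one dose given (going by the name of the read-out) and lower numbers for less inhibition. Compound 3 `Fc1ccc(C2=NNC(c3cn(-c4ccccc4)nc3-c3ccc(Cl)c(Cl)c3)C2)cc1` gives 46.1%. Compound 1 `O=CN1N=C(c2ccc(F)cc2)CC1c1cn(-c2ccccc2)nc1-c1ccc(Cl)c(Cl)c1` gives 60.9%; the step of a number 14.8 percentage points higher from compound 3 to compound 1 (beyond the scatter) is the change (formyl in place of hydrogen on an amine nitrogen in a ring). Compound 2 `Cc1ccc(C2=NNC(c3cn(-c4ccccc4)nc3-c3ccc(Cl)c(Cl)c3)C2)cc1` gives 48.4%; the step of a number 2.3 percentage points lower from compound 2 to compound 3 (within the scatter) is the difference between the two cores, (methyl in place of fluoro on an aromatic carbon), and it lies within the scatter, so compound 2 and compound 3 are not separated on this read-out.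

Compound 4 `Cc1ccc(C2=NN(C=O)C(c3cn(-c4ccccc4)nc3-c3ccc(Cl)c(Cl)c3)C2)cc1` is not yet measured in this assay. It differs from compound 2 by formyl in place of hydrogen on an amine nitrogen in a ring, the same kind of change as from compound 3 to compound 1; the two places differ only in that the ring atom two ring bonds away bears a 4-methylphenyl group in compound 4 and a 4-fluorophenyl group in compound 1. Among the four compounds this change occurs twice. For the measured compounds named here, the step expected from compound 2 to compound 4 is about a number 13.6 percentage points higher from compound 2 to compound 4 (beyond the scatter), set beside the single precedent a number 14.8 percentage points higher from compound 3 to compound 1 (beyond the scatter), which is the only step of this kind available. Compound 4 is therefore expected to give roughly 62%, between 50% and 74%, resting on that one precedent alone.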

Compound 4, a percentage reported as inhibition, in the whole organism at one dose (the size of the read-out at that dose, not a potency): 60.9%
Estimate against measurement, compound 4: 1.1 percentage points above, within the range that was stated.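

In this assay, formyl in place of hydrogen on the ring amine nitrogen again gives a rise, with a number 12.5 percentage points higher from compound 2 to compound 4 (beyond the scatter), and its size carries from one core to the other: the same change on two cores in this assay, a number 14.8 percentage points higher (beyond the scatter) from compound 3 to compound 1 and a number 12.5 percentage points higher (beyond the scatter) from compound 2 to compound 4, 2.3 percentage points apart, within the scatter of two such steps. Methyl in place of fluoro on the aromatic carbon leaves the two formyl compounds unseparated, with no change at the digits printed from compound 1 to compound 4 (within the scatter), just as it leaves the two compounds with hydrogen on that nitrogen unseparated: the same change on two cores in this assay, a number 2.3 percentage points lower (within the scatter) from compound 2 to compound 3 and no change at the digits printed (within the scatter) from compound 4 to compound 1, 2.3 percentage points apart, within the scatter of two such steps. For the compounds shown here, this shows that the two changes act independently within these four compounds, but it covers only two cores that differ in a single group, at one dose, and it does not show that the step would hold on a core changed elsewhere or explain why formyl gives it.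

Still open, from the compounds shown here alone, is whether an acetyl group or a longer acyl chain on that nitrogen would give the same step. Also open, going by these compounds, is whether an amine or a carboxylic acid in place of methyl or fluoro on the aromatic carbon would keep it.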